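The compounds below may be only part of what the source reports. "The series", "measured", "known", "first", "only" and "open" are said of these compounds alone.

Of the compounds shown here, three sharing one core have been measured in a functional assay on BCG823 cells (Homo sapiens) for inhibition, read by MTT assay, with a stated time of 72 h; a lower number here means a stronger inhibitor, a higher number a weaker inhibitor. Compound 1 `CN(C(=O)NC(=O)c1ccc(C(F)(F)F)cc1)c1nc(C(F)(F)F)c(C(=O)N/N=C/c2cccc(C(F)(F)F)c2)s1` gives 1.84 ug/mL. Compound 2 `CN(C(=O)NC(=O)c1ccc(Cl)cc1Cl)c1nc(C(F)(F)F)c(C(=O)N/N=C/c2ccccc2C(F)(F)F)s1` gives 5.73 ug/mL. Compound 3 `CN(C(=O)NC(=O)c1c(F)cccc1F)c1nc(C(F)(F)F)c(C(=O)N/N=C/c2ccccc2C(F)(F)F)s1` gives 17 ug/mL, the highest of the three numbers, so on this set it is the weakest inhibitor, with compound 2 nearest and compound 1 furthest away. Among the measured compounds shown here, the only single-point step among the measured compounds is a 3.0-fold higher number from compound 2 to compound 3 (0.47 log units; beyond the scatter), showing that exchanging the aryl group on the carbonyl carbon of the acyl part moves the number by a modest but real amount.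

Compound 4 `CN(C(=O)NC(=O)c1ccc(C(F)(F)F)cc1)c1nc(C(F)(F)F)c(C(=O)N/N=C/c2ccccc2C(F)(F)F)s1` is not yet measured. It differs from compound 3 in one place: 4-(trifluoromethyl)phenyl in place of 2,6-difluorophenyl on a carbonyl carbon. For the measured compounds named here, that same 4-(trifluoromethyl)phenyl group on the carbonyl carbon is the one carried by compound 1, which gave the lowest number in this assay; compound 4 keeps the rest of compound 3 unchanged. Since the acyl aryl exchange from compound 2 to compound 3 already gave a clear step, and since compound 1 with the entering group sits well below compound 3, a drop in the number beyond the scatter is expected, estimated at a 3.8-fold lower number from compound 3 to compound 4 (0.58 log units; beyond the scatter). Compound 4 is therefore expected to give about 4.5 ug/mL in this assay, within a range from 1.5 ug/mL to 13 ug/mL.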

Compound 4, half-maximal inhibitory concentration: 2.53 ug/mL
Estimate against measurement, compound 4: 1.8-fold (0.25 log units) above; low and high end bracket the measured number.
By their numbers in this assay, from the lowest: compounds 1 and 4 (each within the scatter of the next); then compound 2; then compound 3.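

With the 2-(trifluoromethyl)phenyl end held fixed, three aryl groups on the carbonyl carbon can now be ranked in this assay. Placing 4-(trifluoromethyl)phenyl there in place of 2,6-difluorophenyl gives a 6.7-fold lower number from compound 3 to compound 4 (0.83 log units; beyond the scatter) and in place of 2,4-dichlorophenyl gives a 2.3-fold lower number from compound 2 to compound 4 (0.36 log units; beyond the scatter) in the same assay, so both steps favour the entering group and this position matters more than the single earlier step could show. Among the compounds shown here, the other end of the molecule can now be read for the first time: 2-(trifluoromethyl)phenyl in place of 3-(trifluoromethyl)phenyl on a carbon with a double bond to nitrogen gives a 1.4-fold higher number from compound 1 to compound 4 (0.14 log units; within the scatter) and so does not separate the two compounds. Nothing measured here bears on why the group on the carbonyl carbon changes the number.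

Going by these compounds, all three groups on the carbonyl carbon are phenyl rings carrying fluorine or chlorine, so it remains open how a plain phenyl, a methoxy-bearing phenyl or a longer alkyl chain would behave there. On these data alone, it is also open whether the same ranking of these groups would hold with 3-(trifluoromethyl)phenyl at the other end of the molecule.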